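A few compounds are considered here, and "the series" means these few. Any claim that something is new, unique, unknown or untested is made for them only; others in the source may bear on it.

Measured so far, in an ADME assay on Vero cells (Chlorocebus sabaeus) for cytotoxicity, read by MTT assay, with a stated time of 72 h; a lower number here means that less compound is tolerated, a higher number that more compound is tolerated:
Compound 1 `CCCOc1ccc(C(=O)/C=C/c2ccc(C(=O)Nc3cccc(-c4cc(C(=O)OC)no4)c3)cc2)cc1` gives > 40 ug/mL, which is a limit of the assay and not a number.
Compound 2 `COC(=O)c1cc(-c2cccc(NC(=O)c3ccc(/C=C/C(=O)c4ccc(C)c(F)c4)cc3)c2)on1` gives > 50 ug/mL, also a limit of the assay.
Compound 3 `COC(=O)c1cc(-c2cccc(NC(=O)c3ccc(/C=C/C(=O)c4ccc(F)cc4F)cc3)c2)on1` gives > 40 ug/mL, again a limit of the assay.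

Compound 3 therefore stands only at a limit in this assay, and the other two compounds stand at limits as well, so no ordering among the three can be read. The change to compound 4 `COC(=O)c1cc(-c2cccc(NC(=O)c3ccc(/C=C/C(=O)c4ccc(OC)cc4OC)cc3)c2)on1` is 2,4-dimethoxyphenyl in place of 2,4-difluorophenyl on a carbonyl carbon. The measured steps that bear on it are those at the same place: a step that the two limits leave unreadable from compound 1 to compound 3, a step that the two limits leave unreadable from compound 2 to compound 3 and a step that the two limits leave unreadable from compound 1 to compound 2, none of which has a readable size. Two of the three values sit at the limit of > 40 ug/mL in this assay, at which 2 of the 3 values shown sit, and one at the limit of > 50 ug/mL in this assay, at which 1 of the 3 values shown sits. No direction can be read from these, and the expectation is that compound 4 will again reach a limit rather than a number. In this assay compound 4 is expected to give about 45 ug/mL, estimated between 25 ug/mL and 80 ug/mL. The expected step that the limit leaves unreadable from compound 3 to compound 4 is none beyond the scatter.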

Compound 4, half-maximal cytotoxic concentration: > 50 ug/mL
Compound 4 ended at the assay's limit; the forecaster's own chance of this, stated with the estimate: 80%; at least 1.1-fold (0.04 log units) between middle value and limit.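

In this assay compound 4 gives > 50 ug/mL, a limit of the assay and not a number. Among these compounds, compound 1, compound 2, compound 3 and compound 4 all stand at limits, so no step among them can be read. The compounds shown leave open whether the group on the carbonyl carbon changes tolerance at all.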